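The compounds below may be only part of what the source reports. "The series", "measured", "known", "first", "only" and "open" are said of these compounds alone.

Measured compounds:
compound 1 `CC(C)=CCC[C@]1(C)/C=C/[C@@H](OC(=O)C=C(C)C)[C@](C)(O)/C=C/C(=O)/C(CN(C(C)C)C(C)C)=C\C1`, 650 nM
compound 2 `CC(C)=CCC[C@]1(C)/C=C/[C@@H](OC(=O)C=C(C)C)[C@](C)(O)/C=C/C(=O)/C(C[Si](c2ccccc2)(c2ccccc2)C(C)(C)C)=C\C1`, 13000 nM
compound 3 `CC(C)=CCC[C@]1(C)/C=C/[C@@H](OC(=O)C=C(C)C)[C@](C)(O)CCC(=O)/C(CO)=C\C1`, a limit

In a functional assay on A549 cells (Homo sapiens) for antiproliferative activity, read by MTT assay, with a stated time of 48 h (a lower number here means a stronger inhibitor, a higher number a weaker inhibitor), compound 1 gives 650 nM, the lowest of the two numbers seen. The nearest neighbour, compound 2, gives 13000 nM, a gap beyond the scatter. Compound 3 gives > 40000 nM, which is a limit and not a number. Compound 3 reaches only (the limit of > 40000 nM in this assay, at which 1 of the 3 values shown sits), so it contributes a limit and no number. Compound 4 `CCN(CC)C(=O)/C1=C/C[C@](C)(CCC=C(C)C)/C=C/[C@@H](OC(=O)C=C(C)C)[C@](C)(O)/C=C/C1=O` is not yet measured. It differs from compound 1 in one place: diethylcarbamoyl in place of (diisopropylamino)methyl on a double-bonded ring carbon. Among the compounds with values here, no measured pair isolates this change, so the direction is uncertain; on balance a move toward weaker inhibition beyond the scatter is expected, and the step of a 12-fold higher number from compound 1 to compound 4 (1.09 log units; beyond the scatter) is the estimate. Compound 4 is therefore expected to give about 8000 nM, between 2000 nM and 40000 nM.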

Compound 4, half-maximal inhibitory concentration: 11300 nM
Beside the measured number, compound 4's estimate is 1.4-fold (0.15 log units) below it; low and high end bracket the measured number.
By their numbers in this assay, from the lowest: compound 1; then compounds 4 and 2 (each within the scatter of the next). At a limit, above all of these: compound 3.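

Diethylcarbamoyl in place of (diisopropylamino)methyl on a double-bonded ring carbon gives a 17-fold higher number from compound 1 to compound 4 (1.24 log units; beyond the scatter) in this assay, the first single-place change in this set. The group at this ring carbon therefore matters for the antiproliferative read-out, and in this one pair the amine-bearing group gives the lower number. Nothing measured here accounts for the size of this step. The compounds shown leave open whether the carbonyl or the alkyl groups on nitrogen carry the step, which (diethylamino)methyl would separate. They also leave open how a cyclic amine such as piperidin-1-ylmethyl would compare with compound 1.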